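Replacing a formylphenyl with naphthalenyl on a shared core

The source may hold more compounds than are shown below. What is called first, only, known or untested is meant among the compounds shown, and "the series" means these compounds.

Measured so far:
compound 1 `c1ccc2c(-c3cn4ccnc4c(-c4ccc5ncn(C6CCCCC6)c5c4)n3)cccc2c1`, 6.49%
compound 2 `CCc1ccc(-c2cn3ccnc3c(-c3ccc4ncn(Cc5ccccc5)c4c3)n2)cc1`, 44.7%
compound 3 `O=Cc1ccc(-c2cn3ccnc3c(-c3ccc4ncn(Cc5ccccc5)c4c3)n2)cc1`, 11.6%

In a functional assay on ACHN cells (Homo sapiens) for inhibition, read by sulforhodamine B assay, with a stated time of 48 h, tested at 10 uM (on this read-out lower numbers stand for less inhibition and higher numbers for more inhibition at the one concentration tested (going by the name of the read-out)), compound 3 gives 11.6%, the second highest of the three numbers, within the scatter of compound 1 and well under compound 2. Compound 4 `c1ccc(Cn2cnc3ccc(-c4nc(-c5cccc6ccccc56)cn5ccnc45)cc32)cc1` has not yet been measured; it differs from compound 3 by naphthalen-1-yl in place of 4-formylphenyl on an aromatic carbon. For the measured compounds named here, the only measured step at that position is a number 33.1 percentage points lower from compound 2 to compound 3 (beyond the scatter), showing that exchanging the group on this aromatic carbon can move the read-out a lot. Going by the values given here, no step covers naphthalenyl directly; compound 1, which also carries naphthalen-1-yl but a different group elsewhere, gives 6.49%. A modest rise is therefore expected for compound 4, estimated at 20% (range 2% to 48%), an expected step of a number 8.4 percentage points higher from compound 3 to compound 4 (within the scatter).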

Compound 4, a percentage reported as inhibition, at one concentration (the size of the read-out at that concentration, not a potency): 12.4%
Compound 4: the middle estimate sits 7.6 percentage points above what was measured, within the range that was stated.
By their numbers in this assay, from the lowest: compounds 1, 3 and 4 (each within the scatter of the next); then compound 2.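

In this assay, naphthalen-1-yl and 4-formylphenyl on this aromatic carbon cannot be told apart: the exchange gives a number 0.8 percentage points higher from compound 3 to compound 4 (within the scatter). Replacing 4-ethylphenyl with naphthalen-1-yl gives a much bigger change, a number 32.3 percentage points lower from compound 2 to compound 4 (beyond the scatter), so a second group now falls well short of 4-ethylphenyl. With naphthalen-1-yl in both compounds, benzyl in place of cyclohexyl on the aromatic nitrogen gives a number 5.9 percentage points higher from compound 1 to compound 4 (within the scatter).

Nothing available explains why 4-ethylphenyl stands apart. From the compounds shown here alone, whether a longer chain, as in 4-propylphenyl, or an amine in place of the ethyl group would match compound 2 remains open.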